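Adding a Methoxy Group to a Weakly Active Thiosemicarbazone

The compounds below may be only part of what the source reports. "The series", "measured", "known", "first", "only" and "open" are said of these compounds alone.

Measured compounds:
compound 1, `CC1=CC[C@H](C(C)(C)NC(=S)N/N=C/c2ccccc2)CC1`: 26300 nM
compound 2, `COc1ccc(/C=N/NC(=S)NC(C)(C)[C@H]2CC=C(C)CC2)cc1`: 11400 nM
compound 3, `CC1=CC[C@H](C(C)(C)NC(=S)N/N=C(\C)c2ccccc2)CC1`: only a limit, > 100000 nM

All three were tested in a functional assay on U-251 cells (Homo sapiens) for inhibition, read by sulforhodamine B assay, with a stated time of 48 h; on this read-out higher numbers stand for weaker inhibition of growth and lower numbers for stronger inhibition of growth. Between compound 1 and compound 2 the change is methoxy in place of hydrogen on an aromatic carbon, and the step is a 2.3-fold lower number from compound 1 to compound 2 (0.36 log units; beyond the scatter). Compound 3 gave no number in this assay, only a limit, (the limit of > 100000 nM in this assay, at which 1 of the 3 values shown sits). How the core of compound 3 differs from that of compound 1 is not broken down here.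

Compound 4, `COc1ccc(/C(C)=N/NC(=S)NC(C)(C)[C@H]2CC=C(C)CC2)cc1`, is not yet measured. It differs from compound 3 by methoxy in place of hydrogen on an aromatic carbon, the same change seen between compound 1 and compound 2. Since compound 3 sits at a limit, the step from compound 3 to compound 4 is expected to be about an at least 1.2-fold lower number from compound 3 to compound 4 (0.09 log units; that floor lies within the scatter), resting on the modest gain of a 2.3-fold lower number from compound 1 to compound 2 (0.36 log units; beyond the scatter). Compound 4 is therefore estimated at 80000 nM, between 30000 nM and 300000 nM, and a limit rather than a number is quite possible.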

Compound 4, concentration for 50% growth inhibition: 43400 nM
Beside the measured number, compound 4's estimate is 1.8-fold (0.27 log units) above it, and the stated range covers the measured number.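

Swapping phenyl for 4-methoxyphenyl in this assay gives stronger growth inhibition on both cores shown, and the new pair adds an at least 2.3-fold lower number from compound 3 to compound 4 (0.36 log units; beyond the scatter). Set side by side, the two steps read: the same change on two cores in this assay, a 2.3-fold lower number (0.36 log units; beyond the scatter) from compound 1 to compound 2 and an at least 2.3-fold lower number (0.36 log units; beyond the scatter) from compound 3 to compound 4; the limit leaves it open whether they differ. For compound 3 the entry > 100000 nM is a limit and not a number, so the new step has a floor but no exact size, and two cores cannot show that the gain would carry to every core in this series.

The compounds shown leave open whether an amine, a hydroxyl or a longer chain such as ethoxy in place of the methoxy group would lower the number as well. They also leave open whether these steps would hold in other cell types.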